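This account rests on a few compounds, and the source may have more. Where it says the series, first, only, none or still open, it means among the compounds named here.

Measured compounds:
compound 1 `C[C@H]1O[C@H](CO)[C@@H](O)[C@H](O)[C@H]1O`, 50100000 nM
compound 2 `NCC[C@@H]1O[C@H](CO)[C@@H](O)[C@H](O)[C@H]1O`, 5010000 nM
compound 3 `N#CC[C@]1(O)O[C@H](CO)[C@@H](O)[C@H](O)[C@H]1O`, 7940000 nM

All three were examined in an assay on isolated protein (Sus scrofa) for inhibition of glycogen phosphorylase, brain form (Homo sapiens); on this read-out lower numbers stand for stronger inhibition and higher numbers for weaker inhibition. Compound 1 stands at the highest number of the three. Compound 3 gives 7940000 nM, a lower number than compound 1 by a margin that lies beyond the usual scatter of this assay. Compound 2 gives 5010000 nM, and its gap to compound 1 is wider still, also beyond the scatter. Compound 1 is therefore the weakest of the three on this read-out, with compounds 2 and 3 both clearly ahead of it; between compounds 2 and 3 themselves the numbers are close and nothing further is said about their order.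

The next compound, compound 4 `NC(=O)N[C@H]1O[C@H](CO)[C@@H](O)[C@H](O)[C@H]1O`, has not yet been measured in this assay. It is derived from compound 1 by a single change: ureido in place of methyl on a saturated ring carbon. Among the measured compounds shown here, no measured pair in this set shows the same exchange, so the size of the step can only be judged from the general picture. Both compounds that carry a larger, more heavily substituted group at that position, compound 2 and compound 3, give lower numbers than compound 1, and on that basis a step from compound 1 to compound 4 of a 33-fold lower number from compound 1 to compound 4 (1.52 log units; beyond the scatter) towards a lower number is expected. Compound 4 is thus estimated to reach 1500000 nM, with a plausible range from 250000 nM to 8000000 nM.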

Compound 4, inhibition constant: 126000 nM
Compound 4: the middle estimate sits 12-fold (1.08 log units) above what was measured; measured number below the stated range.
By their numbers in this assay, from the lowest: compound 4; then compounds 2 and 3 (each within the scatter of the next); then compound 1.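

Ureido in place of methyl on a saturated ring carbon, next to the ring oxygen, brings a 400-fold lower number from compound 1 to compound 4 (2.60 log units; beyond the scatter) in this assay and gives the first single-change step that can be read in this set. It shows that this position accepts a group with more heavy atoms than methyl, one that also brings hydrogen-bond donors and an acceptor, and that the read-out is highly sensitive to what stands there on an otherwise unchanged core. The data show the size and direction of this one exchange, but no measurement is available that explains why the step is so large.

The compounds shown do not tell which part of the ureido group goes with the step, since no compound separates its carbonyl from its terminal amino group or from the nitrogen joined to the ring carbon. An amine or an acetamide at the same ring carbon would address that question, while a carboxylic acid or a longer urea chain would show whether the step holds for other groups at this position.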